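A few compounds are considered here, and "the series" means these few. Any claim that something is new, unique, unknown or untested is made for them only; others in the source may bear on it.

In a functional assay on HCT-116 cells (Homo sapiens) for cytotoxicity, read by resazurin assay, with a stated time of 48 h (on this read-out higher numbers stand for an effect only at larger amounts of compound and lower numbers for an effect already at smaller amounts), compound 1 (`COc1ccc(S(=O)(=O)Nc2ccc3oc(-c4ccc(NC(=O)c5cccc(C)c5[N+](=O)[O-])cc4)nc3c2)cc1`) gives 4400 nM. For the measured compounds named here, compound 2 (`COc1c(Br)cccc1C(=O)Nc1ccc(Sc2nc3ccccc3s2)cc1`), the only other compound measured so far, gives 31000 nM, which leaves compound 1 with the lower of the two numbers, by a gap beyond the usual scatter. Compound 3 (`COc1ccc(S(=O)(=O)Nc2ccc3oc(-c4ccc(NS(=O)(=O)c5cc(F)ccc5OC)cc4)nc3c2)cc1`) keeps the core of compound 1 and differs in one place, on a nitrogen on an aromatic ring: the (3-methyl-2-nitrophenyl)carbonyl group leaves and a group holding sulfur and fluorine enters (a group of 12 heavy atoms (7 carbon, 3 oxygen, 1 fluorine, 1 sulfur; one six-membered aromatic ring of carbon only) in place of a group of 12 heavy atoms (8 carbon, 1 nitrogen, 3 oxygen; one six-membered aromatic ring of carbon only), on a nitrogen on an aromatic ring). Going by the values given here, no measured pair of compounds shows what such a swap does, so the expectation rests on compound 1 alone. The expected step in this assay is a 1.4-fold higher number from compound 1 to compound 3 (0.13 log units; within the scatter), which means none beyond the scatter. For compound 3 the estimated value is 6000 nM, with an expected range from 1500 nM to 24000 nM.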

Compound 3, half-maximal effective concentration: 15000 nM
For compound 3 the middle estimate is 2.5-fold (0.40 log units) below the measured one; low and high end bracket the measured number.
By their numbers in this assay, from the lowest: compound 1; then compound 3; then compound 2.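

In this assay, the group on the nitrogen on an aromatic ring proves to matter: swapping the (3-methyl-2-nitrophenyl)carbonyl group for the group holding sulfur and fluorine gives a 3.4-fold higher number from compound 1 to compound 3 (0.53 log units; beyond the scatter), a modest step, but one beyond the scatter. The two groups match in heavy-atom count, hydrogen-bond donors and acceptors, and lack of net charge, so these counts alone do not set the number at this position. No measurement at hand says why the number moves.

The swap replaces the carbonyl link and the ring's substituents together, so the compounds shown leave open which of these parts carries the step. On these data alone, how a small acetyl group or a bare amine on this nitrogen would read in this assay also remains open.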